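The source may report more compounds than this note shows. Statements on the series, on what has been measured and on what is new or still open speak of the compounds shown alone.

Measured compounds:
compound 1 `C=C[C@@](C)(/C=C/c1ccc(OC)cc1)CCC=C(C)C`: > 36600 nM
compound 2 `C=C[C@@](C)(/C=C/c1ccc(O)cc1)CC/C=C/C(=O)OCc1ccccc1`: > 36600 nM
compound 3 `COc1ccc(/C=C/[C@@](C)(/C=C/c2ccc(O)c(/C=C/C#N)c2)CCC=C(C)C)cc1`: > 36600 nM

All three readings come from an ADME assay on HEK293 cells (Homo sapiens) for cytotoxicity, with a stated time of 72 h; on this read-out lower numbers stand for an effect already at smaller amounts and higher numbers for an effect only at larger amounts of compound. In this assay compound 1 gives > 36600 nM, which is a limit of the assay and not a number. Compound 1 therefore has no exact position in the series, and the whole measured set shares one reading: the limit of > 36600 nM in this assay, at which 3 of the 3 values shown sit. Among the measured compounds shown here, no compound can be ranked against another on these readings, and no measured step is available for comparison.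

The next compound is compound 4 `C=C[C@@](C)(/C=C/c1ccc(Nc2ccccc2)cc1)CCC=C(C)C`. It carries anilino in place of methoxy on an aromatic carbon of the core of compound 1, para to a large group: anilino in place of methoxy on an aromatic carbon. For the measured compounds named here, nothing measured so far shows what this exchange does in this assay, so the expectation rests only on the shared limit. Compound 4 is expected to read at the same limit, or else to give a number not far under it. Any expected shift is therefore toward lower numbers, and a large step is not expected. The expected at least 1.2-fold lower number from compound 1 to compound 4 (0.08 log units; that floor lies within the scatter) is small. For compound 4 the estimated value is 30000 nM, with an expected range of 10000 nM to 60000 nM.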

Compound 4, half-maximal effective concentration: > 36600 nM
Compound 4: a limit, no number; the forecaster's own chance of this, stated with the estimate: 65%; middle value at least 1.2-fold (0.08 log units) from the limit.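

In this assay compound 4 gives > 36600 nM, which is a limit and not a number. Compound 1 also reads at a limit, so no new step can be read between compound 1 and compound 4. The compounds shown leave open whether anilino in place of methoxy on an aromatic carbon changes the reading at all, and where any compound would give a number.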